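Acyl variation on the piperazine amide of compound 1

This account rests on a few compounds, and the source may have more. Where it says the series, first, only, none or still open, it means among the compounds named here.

Measured so far:
compound 1 `CCc1ccc(C(=O)N2CCN(Cc3nc4ccccc4n3Cc3cccc(C)c3)CC2)cc1` — 67%
compound 2 `O=C(C1CC1)N1CCN(Cc2nc3ccccc3n2Cc2ccccc2C(F)(F)F)CC1` — 56.3%
compound 3 `O=C(C1CC1)N1CCN(Cc2nc3ccccc3n2CC2CC2)CC1` — 21.2%

In an assay on isolated protein for inhibition of aldehyde dehydrogenase 1A1 (Homo sapiens), read by spectrophotometry, tested at 10 uM (a higher number here means more inhibition at the concentration tested (going by the name of the read-out), a lower number less inhibition), compound 1 gives the highest of the three numbers; compound 2 lies nearest, compound 3 furthest, and both gaps are beyond the scatter. For the measured compounds named here, the only step between compounds that differ in one place is a number 35.1 percentage points lower from compound 2 to compound 3 (beyond the scatter), and it concerns the group on the saturated chain carbon bound to the aromatic nitrogen, not the acyl group on the piperazine.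

Compound 4 `Cc1cccc(Cn2c(CN3CCN(C(=O)c4ccco4)CC3)nc3ccccc32)c1` differs from compound 1 by furan-2-yl in place of 4-ethylphenyl on a carbonyl carbon. Going by the values given here, no measured step touches the carbonyl carbon, so nothing here tells how much the number changes with a change at this position; compound 2 carries a cyclopropyl at the same carbonyl carbon but also a different group on the aromatic nitrogen, so its value cannot be read against compound 1 alone. Among the compounds with values here, with no bearing step, the expectation for compound 4 is a modest decrease, a number 15 percentage points lower from compound 1 to compound 4 (beyond the scatter), with a wide range. Compound 4 is therefore estimated at 52%, between 30% and 72%.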

Compound 4, a percentage reported as inhibition, at one concentration (the size of the read-out at that concentration, not a potency): 73.2%
Compound 4: middle estimate off by 21.2 percentage points, on the low side; measured number above the stated range.
By their numbers in this assay, from the lowest: compound 3; then compound 2; then compounds 1 and 4 (each within the scatter of the next).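

Working notes: in this assay, the first readable step at the carbonyl carbon is a number 6.2 percentage points higher from compound 1 to compound 4 (within the scatter) and shows that this position takes furan-2-yl in place of 4-ethylphenyl without a change separable from scatter. In this pair, going from 8 heavy atoms to 5 and from a six-membered to a five-membered aromatic ring, with 1 hydrogen-bond acceptor entering, leaves the inhibition level intact. No measured evidence on the origin of this result is available.

Still open, as far as these compounds go, is how a non-aromatic acyl group, such as the cyclopropyl carbonyl of compound 2, reads with the aromatic nitrogen substituent of compound 1 held constant. Also open, from the compounds shown here alone, is the outcome of a basic amine or a carboxylic acid attached to the aromatic ring on this carbonyl carbon.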